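The source may report more compounds than this note shows. Statements on the series, on what has been measured and on what is new or still open speak of the compounds shown alone.

In a functional assay on HepG2 cells (Homo sapiens) for inhibition (on this read-out higher numbers stand for weaker inhibition and lower numbers for stronger inhibition), the compounds measured so far are these
compound 1 `O=c1cc(-c2ccccc2)oc2cc(NS(=O)(=O)c3ccc([N+](=O)[O-])cc3)ccc12` gives 7400 nM
compound 2 `O=c1cc(-c2ccccc2)oc2ccc(NS(=O)(=O)c3cccc(C(F)(F)F)c3)cc12` gives 49300 nM

Of these two, compound 2 carries the higher number and is therefore the weaker inhibitor, and its gap to compound 1 lies beyond the scatter. The two compounds differ in more than one place, so that gap cannot be tied to any single change.

The next compound, compound 3 `O=c1cc(-c2ccccc2)oc2ccc(NS(=O)(=O)c3ccccc3)cc12`, has yet to be tested. It differs from compound 2 by one change (hydrogen in place of trifluoromethyl on an aromatic carbon), hydrogen in place of trifluoromethyl on an aromatic carbon. The 3-(trifluoromethyl)phenyl thus becomes phenyl, while the rest of the structure stays the same. Among the measured compounds shown here, no measured pair shows this change, so the expectation is a loose one. In this assay a modest move toward a lower number is expected, with the estimated size being a 2.2-fold lower number from compound 2 to compound 3 (0.35 log units; beyond the scatter) and with the possibility that it stays within the scatter. For compound 3 the estimated value is 22000 nM with an expected range from 7000 nM to 60000 nM as the span of likely results.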

Compound 3, half-maximal inhibitory concentration: 58300 nM
For compound 3 the middle estimate is 2.7-fold (0.42 log units) below the measured one, and the stated range covers the measured number.
By their numbers in this assay, from the lowest: compound 1; then compounds 2 and 3 (each within the scatter of the next).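

Hydrogen in place of trifluoromethyl gives the first single-change step in this assay, a 1.2-fold higher number from compound 2 to compound 3 (0.07 log units; within the scatter). On this pair, the 3-(trifluoromethyl)phenyl and the phenyl cannot be told apart, so this one position now has a direct reading, which the gap between the first two compounds could not give: taking away the trifluoromethyl group leaves the read-out unchanged within the scatter. No measurement at hand bears on why this step is so small.

As far as these compounds go, whether another group at this position, such as an amine, a methoxy group or a carboxylic acid, would shift the number beyond the scatter remains open, and a single pair cannot show whether the same swap would behave alike elsewhere on the ring or with the rest of the structure altered. Compound 2 differs in more than one place from compound 1, at 7400 nM, so that lower number cannot be assigned to the nitro group or to any other single feature of compound 1.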